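Arylsulfonamide thiazoles: cytotoxicity notes, compound 4 pending

The source may report more compounds than this note shows. Statements on the series, on what has been measured and on what is new or still open speak of the compounds shown alone.

compound 1 `O=S(=O)(Nc1ncc(C(Oc2ccc3cc(Br)ccc3c2)c2ccc(Cl)cc2)s1)c1cccs1`: "not toxic" (no number reported)
compound 2 `Cc1ccc(C)c(S(=O)(=O)Nc2ncc(C(Oc3ccc4cc(Br)ccc4c3)c3ccc(Cl)cc3)s2)c1`: > 50000 nM
compound 3 `O=S(=O)(Nc1ncc(C(Oc2ccc3cc(Br)ccc3c2)c2ccc(Cl)cc2)s1)c1ccc(Cl)cc1`: "not toxic" (no number reported)

In an ADME assay on HepG2 2.2.15 cells (Homo sapiens) for cytotoxicity (on this read-out lower numbers stand for higher toxicity in this test and higher numbers for lower toxicity in this test), compound 1 gives "not toxic" (no number reported). Compound 2 reaches only a limit of this assay, > 50000 nM. Compound 3 gives "not toxic" (no number reported), an entry without a single number; among the three results, one sits at the limit of > 50000 nM in this assay, at which 1 of the 3 values shown sits, and none carries a plain number, so compound 3 cannot be placed on a scale against the others. Compound 4 `O=S(=O)(Nc1ncc(C(Oc2ccc3cc(Br)ccc3c2)c2ccc(Cl)cc2)s1)c1ccc2ccccc2c1` differs from compound 3 by naphthalen-2-yl in place of 4-chlorophenyl on a sulfonyl sulfur, in words naphthalen-2-yl in place of 4-chlorophenyl on a sulfonyl sulfur. Within the data shown here, no step between measured compounds exists to gauge such a change. In this assay the expectation for compound 4 is no shift beyond the scatter, most probably again a limit rather than a number. Compound 4 is estimated at 60000 nM, within 25000 nM to 150000 nM.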

Compound 4, half-maximal cytotoxic concentration: > 50000 nM
Compound 4: a limit, no number; the forecaster's own chance of this, stated with the estimate: 80%; the middle value is on the limit's open side.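

In this assay, no step can be read from compound 2 to compound 4, since both results are limits: the limit of > 50000 nM in this assay, at which 2 of the 4 values shown sit.

On these data alone, whether any group on the sulfonyl sulfur changes this read-out stays open, with no plain number among the four compounds.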